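The source may report more compounds than this note shows. Statements on the series, on what has been measured and on what is new or still open speak of the compounds shown alone.

Measured compounds:
Compound 1 `Nc1cc(N)c2nc(-c3ccccc3)c(NCc3ccc(Cl)c(Cl)c3)nc2c1`: 1740 nM
Compound 2 `Nc1cc(N)c2nc(-c3ccccc3)c(NCc3ccc(F)cc3)nc2c1`: 3470 nM

Both numbers come from a functional assay on PC-3 cells (Homo sapiens) for inhibition, read by sulforhodamine B assay, with a stated time of 48 h; a higher number here means a weaker inhibitor of growth, a lower number a stronger inhibitor of growth. Compound 2 has the higher of the two numbers, but the step of a 2.0-fold higher number from compound 1 to compound 2 (0.30 log units; within the scatter) lies within the scatter, so the two compounds cannot be told apart on these data. Compound 3 `Nc1cc(N)c2nc(-c3ccccc3)c(Sc3ccc(F)cc3)nc2c1` keeps the shared core and its phenyl group and changes the group on the aromatic carbon: (4-fluorophenyl)sulfanyl in place of (4-fluorobenzyl)amino on an aromatic carbon. For the measured compounds named here, the only measured step, a 2.0-fold higher number from compound 1 to compound 2 (0.30 log units; within the scatter), alters just the aromatic ring of the (4-fluorobenzyl)amino group and keeps that group's attachment unchanged, so it does not speak to this exchange. Going by the values given here, no measured step bears directly on the change, and the size of the step in this assay cannot be read from the data; a step of some size in either direction is possible. Compound 3 is estimated at 5000 nM, with a range from 1500 nM to 20000 nM, which means an expected step of a 1.4-fold higher number from compound 2 to compound 3 (0.16 log units; within the scatter).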

Compound 3, concentration for 50% growth inhibition: < 100000 nM
Compound 3 was reported as a limit; the forecaster's own chance of this, stated with the estimate: 10%; the middle value lies beyond the limit too.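

In this assay, for the compounds shown here, compound 3 is reported only as a limit of < 100000 nM and not as a number, so no step from compound 2 to compound 3 can be read. The compounds shown leave open how (4-fluorophenyl)sulfanyl compares with (4-fluorobenzyl)amino in this position.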